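Carbonyl substituent series: fluoro to chloro exchange

A few compounds are considered here, and "the series" means these few. Any claim that something is new, unique, unknown or untested is made for them only; others in the source may bear on it.

The three measured compounds share one core and differ only in the group on the carbonyl carbon. Compound 1 `CN(C(=O)C(C)(C)C)c1ccc2[nH]c(-c3n[nH]c4ccccc34)cc2n1` carries tert-butyl there; in a functional assay on KB cells (Homo sapiens) for antiproliferative activity, read by MTT assay, with a stated time of 72 h (on this read-out higher numbers stand for weaker inhibition and lower numbers for stronger inhibition), compound 1 gives 8390 nM. Compound 2 `CN(C(=O)c1ccccc1)c1ccc2[nH]c(-c3n[nH]c4ccccc34)cc2n1` carries phenyl, and in this assay compound 2 gives 8580 nM. Compound 3 `CN(C(=O)c1ccc(F)cc1)c1ccc2[nH]c(-c3n[nH]c4ccccc34)cc2n1` carries 4-fluorophenyl, and in this assay compound 3 gives 7220 nM. The steps between them are a 1.0-fold higher number from compound 1 to compound 2 (0.01 log units; within the scatter), a 1.2-fold lower number from compound 1 to compound 3 (0.07 log units; within the scatter) and a 1.2-fold lower number from compound 2 to compound 3 (0.07 log units; within the scatter); all three numbers lie within the scatter of one another, so compound 3 stands among them without separating from compound 1 or compound 2.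

Compound 4 `CN(C(=O)c1ccc(Cl)cc1)c1ccc2[nH]c(-c3n[nH]c4ccccc34)cc2n1` is the next member: chloro in place of fluoro on an aromatic carbon. The step that bears most directly on it is the earlier exchange at that aromatic carbon, a 1.2-fold lower number from compound 2 to compound 3 (0.07 log units; within the scatter), where fluoro replaced hydrogen and nothing beyond the scatter followed. The broader exchanges on the carbonyl carbon, a 1.0-fold higher number from compound 1 to compound 2 (0.01 log units; within the scatter) and a 1.2-fold lower number from compound 1 to compound 3 (0.07 log units; within the scatter), were likewise within the scatter. On this footing no step beyond the scatter is expected in this assay, in either direction, for compound 4, meaning a 1.0-fold lower number from compound 3 to compound 4 (0.01 log units; within the scatter). Compound 4 is accordingly estimated at 7000 nM in this assay, with a range from 3500 nM to 14000 nM.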

Compound 4, half-maximal inhibitory concentration: 630 nM
Estimate against measurement, compound 4: 11-fold (1.05 log units) above; measured number below the stated range.
By their numbers in this assay, from the lowest: compound 4; then compounds 3, 1 and 2 (each within the scatter of the next).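

For the compounds shown here, at the aromatic carbon para to a large group, the identity of the halogen matters in this assay: chloro in place of fluoro gives an 11-fold lower number from compound 3 to compound 4 (1.06 log units; beyond the scatter), the first step beyond the scatter, whereas fluoro in place of hydrogen gave only a 1.2-fold lower number from compound 2 to compound 3 (0.07 log units; within the scatter) and stayed within it. Chloro in place of hydrogen gives a 14-fold lower number from compound 2 to compound 4 (1.13 log units; beyond the scatter), and 4-chlorophenyl in place of tert-butyl on the carbonyl carbon gives a 13-fold lower number from compound 1 to compound 4 (1.12 log units; beyond the scatter), so compound 4 separates from all three earlier compounds, which remain within the scatter of one another, and it is the strongest inhibitor of the four. Nothing available on these compounds gives a reason for the size of this single-atom exchange.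

As far as these compounds go, whether this response belongs to chloro alone or extends to bromo, methyl or trifluoromethyl on the same aromatic carbon remains open. Also open, from the compounds shown here alone, is whether the step from 4-fluorophenyl to 4-chlorophenyl carries over when the methyl on the amide nitrogen gives way to an ethyl group or to hydrogen.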